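Trading thiophen-2-yl for furan-2-yl

The compounds below may be only part of what the source reports. "The series", "measured", "known", "first", "only" and "open" are said of these compounds alone.

Compound 1 `COc1cc(/C=C/C(=O)/C=C/c2ccco2)ccc1OCc1cn(CCCOc2cc(=O)oc3ccccc23)nn1` gives 59%
Compound 2 `COc1cc(/C=C/C(=O)/C=C/c2cccs2)ccc1OCc1cn(CCCCCOc2cc(=O)oc3ccccc23)nn1` gives 30%

In a functional assay on COLO 205 cells (Homo sapiens) for inhibition, read by sulforhodamine B assay, with a stated time of 48 h, tested at 50 uM (on this read-out lower numbers stand for less inhibition of growth and higher numbers for more inhibition of growth at the one concentration tested), compound 2 stands lowest of the two numbers at 30% and the gap up to compound 1 lies beyond the scatter. Compound 3 `COc1cc(/C=C/C(=O)/C=C/c2ccco2)ccc1OCc1cn(CCCCCOc2cc(=O)oc3ccccc23)nn1` changes one place of compound 2 as follows: furan-2-yl in place of thiophen-2-yl on a double-bonded chain carbon bound to a double-bonded chain carbon with furan-2-yl in place of thiophen-2-yl. For the measured compounds named here, no measured pair shows this swap alone. Compound 1 at 59% also carries furan-2-yl but differs from compound 3 elsewhere too, so it offers only weak guidance. In this assay the expected a number 7 percentage points higher from compound 2 to compound 3 (within the scatter) is a small rise, probably within the scatter. For compound 3 the estimate is 37% with an expected range from 22% to 55% in this test.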

Compound 3, percent growth inhibition at one concentration: 33%
Beside the measured number, compound 3's estimate is 4 percentage points above it, within the range that was stated.
By their numbers in this assay, from the lowest: compounds 2 and 3 (each within the scatter of the next); then compound 1.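

In this assay, this swap can now be read on its own, with everything else held constant: a number 3 percentage points higher from compound 2 to compound 3 (within the scatter). At this one concentration, compounds carrying thiophen-2-yl and furan-2-yl on this double-bonded chain carbon cannot be told apart, so the two rings serve equally well here in this pair. Nothing available explains this result.

Still open, on these data alone, is whether a phenyl ring or an amine on the same carbon would give a different number. As far as these compounds go, it is also open whether the swap would read the same on the chain carried by compound 1.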